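Removing an acetyl cap: from compound 3 to compound 4

The source may hold more compounds than are shown below. What is called first, only, known or untested is meant among the compounds shown, and "the series" means these compounds.

Measured compounds:
Compound 1 `COc1ccc(Oc2ccc3cc(NC(=O)c4ccc(O)c(CC=C(C)C)c4)c(=O)oc3c2C)cc1` gives 42700 nM in a functional assay on SK-BR-3 cells (Homo sapiens) for antiproliferative activity; a lower number here means a stronger inhibitor, a higher number a weaker inhibitor.
Compound 2 `CC(C)=CCc1cc(C(=O)Nc2cc3ccc(Oc4ccc(C(C)(C)C)cc4)c(C)c3oc2=O)ccc1O` gives 68300 nM in this assay.
Compound 3 `COc1ccc(Nc2ccc3cc(NC(=O)c4ccc(OC(C)=O)c(CC=C(C)C)c4)c(=O)oc3c2C)cc1` reports only a limit in this assay, > 100000 nM.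

Compound 3 thus stands at the weak end of the numbers shown, where (the limit of > 100000 nM in this assay, at which 1 of the 3 values shown sits). Compound 4 `COc1ccc(Nc2ccc3cc(NC(=O)c4ccc(O)c(CC=C(C)C)c4)c(=O)oc3c2C)cc1` differs from it only by hydrogen in place of acetyl on an oxygen on an aromatic ring. Among the measured compounds shown here, the one step measured between two compounds, a 1.6-fold higher number from compound 1 to compound 2 (0.20 log units; within the scatter), concerns a different position, so no measured step covers this change directly. Compound 1 and compound 2, both carrying the free hydroxy, give numbers rather than limits. Compound 4 is therefore expected to land near those two, a step of an at least 1.6-fold lower number from compound 3 to compound 4 (0.22 log units; that floor lies within the scatter). The estimate for compound 4 is 60000 nM, within 20000 nM to 150000 nM.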

Compound 4, half-maximal inhibitory concentration: > 100000 nM
Compound 4: only a limit was reported; the forecaster's own chance of this, stated with the estimate: 40%; middle value at least 1.6-fold (0.22 log units) away from the limit.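

In this assay compound 4 gives > 100000 nM, a limit of the assay and not a number, so the step from acetoxy to hydroxy cannot be read, and this change brings no measurable gain here: the limit of > 100000 nM in this assay, at which 2 of the 4 values shown sit. With the hydroxy kept, (4-methoxyphenyl)amino in place of 4-methoxyphenoxy gives an at least 2.3-fold higher number from compound 1 to compound 4 (0.36 log units; beyond the scatter). In place of 4-(tert-butyl)phenoxy, the same group gives an at least 1.4-fold higher number from compound 2 to compound 4 (0.16 log units; that floor lies within the scatter).

On these data alone, whether a methyl or a longer acyl chain on this oxygen would give a number rather than a limit stays open. So does how acetoxy behaves alongside the 4-methoxyphenoxy group of compound 1.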